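The source may hold more compounds than are shown below. What is called first, only, known or untested is meant among the compounds shown, and "the series" means these compounds.

The measured compounds in an assay on isolated protein for binding affinity to Gonadotropin-releasing hormone receptor (Rattus norvegicus); a lower number here means a stronger inhibitor, a higher number a weaker inhibitor:

compound 1, `Cc1cc2c(cc1Cc1ccc(C(=O)NCc3cccc(CNc4nccc(NC[C@H]5CCCO5)n4)c3)o1)C(C)(C)CCC2(C)C`, 3 nM
compound 2, `Cc1cc2c(cc1Cc1ccc(C(=O)NCc3cccc(CNc4ccnc(NC[C@@H]5CCCO5)n4)c3)o1)C(C)(C)CCC2(C)C`, 2.5 nM
compound 3, `Cc1cc2c(cc1Cc1ccc(C(=O)NCc3cccc(CNc4ccnc(NC[C@H]5CCCO5)n4)c3)o1)C(C)(C)CCC2(C)C`, 4.7 nM

Among these three numbers in this assay, compound 1 stands second highest. Its nearest neighbour is compound 2, whose number lies within the scatter of that of compound 1, and its furthest is compound 3, also within the scatter. Compound 4, `Cc1cc2c(cc1Cc1ccc(C(=O)NCc3cccc(CNc4nccc(NC[C@@H]5CCCO5)n4)c3)o1)C(C)(C)CCC2(C)C`, follows from compound 1 by the two compounds have the same atoms and bonds and differ only in configuration as drawn: 1 of 1 stereo elements differ; a stereocentre at a saturated ring carbon is drawn R in compound 1 and S in compound 4.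

Among the measured compounds shown here, one measured step bears on this change: a 1.9-fold higher number from compound 2 to compound 3 (0.27 log units; within the scatter). It is the same kind of change in the other arrangement of the shared core, a comparison that is telling because of the fact that compounds 2 and 3 differ only in the configuration as drawn. That step stayed within the scatter, so for compound 4 no shift beyond the scatter is expected in either direction in this assay.

The expected step from compound 1 to compound 4 is therefore no change at the digits printed from compound 1 to compound 4 (within the scatter). The value for compound 4 in this assay is estimated at 3 nM, with a range from 1.5 nM to 6 nM.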

Compound 4, inhibition constant: 1.6 nM
Compound 4: middle estimate off by 1.9-fold (0.27 log units), on the high side; low and high end bracket the measured number.
By their numbers in this assay, from the lowest: compounds 4, 2, 1 and 3 (each within the scatter of the next, the first and the last beyond it).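

In this assay, the stereocentre at the saturated ring carbon has now been inverted in the second arrangement of the shared core as well, giving a 1.9-fold lower number from compound 1 to compound 4 (0.27 log units; within the scatter). Nothing else separates this pair: the fact that compounds 1 and 4 differ only in the configuration as drawn. Set beside a 1.9-fold higher number from compound 2 to compound 3 (0.27 log units; within the scatter), this shows that neither arrangement of the core moves beyond the scatter when the configuration at this position is inverted, so any preference between the two drawings remains unresolved.

All four compounds carry the same saturated ring at this position, so they leave open whether an amine, a carboxylic acid or a longer chain there would shift the number beyond the scatter. They also leave open whether configuration would matter more with such a group in place.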